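The source may report more compounds than this note shows. Statements on the series, on what has been measured and on what is new or still open speak of the compounds shown alone.

The account opens with compound 2, `NC(=O)c1ccccc1C(=O)N1CCC(N(C2CC2)S(=O)(=O)c2cccc(C(F)(F)F)c2)CC1`, which in an assay on cells for inhibition of Voltage-dependent L-type calcium channel subunit alpha-1C (Homo sapiens), read by FLIPR and calcium flux, tested at 1 uM (on this read-out higher numbers stand for a stronger effect at the one concentration tested and lower numbers for a weaker effect), gives 11%. On the numbers shown, compound 2 stands lowest of the two compounds that have a number; its nearest neighbour is compound 3, `O=C(c1ccc(OC(F)(F)F)cc1)N1CCC(N(C2CC2)S(=O)(=O)c2cccc(C(F)(F)F)c2)CC1`, which in this assay gives 73%. Going by the values given here, the step between them, a number 62 percentage points higher from compound 2 to compound 3 (beyond the scatter), is the only measured step in the set. A third compound, compound 1, `CS(=O)(=O)c1ccc(C(=O)N2CCC(N(C3CC3)S(=O)(=O)c3cccc(C(F)(F)F)c3)CC2)cc1`, in this assay gives "not determined" (no result reported), no result having been reported for it, so it contributes nothing to the comparison.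

The compound awaiting measurement is compound 4, `CN(C)c1cccc(C(=O)N2CCC(N(C3CC3)S(=O)(=O)c3cccc(C(F)(F)F)c3)CC2)c1`. The difference from compound 2 is 3-(dimethylamino)phenyl in place of 2-carbamoylphenyl on a carbonyl carbon. Among the compounds with values here, the one measured step bears on this change only in part: it also replaces the 2-carbamoylphenyl group on the carbonyl carbon, but the group that enters there is 4-(trifluoromethoxy)phenyl rather than 3-(dimethylamino)phenyl, so the step of compound 2 to compound 3 sets a direction without fixing the size. Because of a number 62 percentage points higher from compound 2 to compound 3 (beyond the scatter), an increase beyond the scatter is expected for compound 4, but a smaller one than the measured step, given the different entering group. Compound 4 is therefore estimated at 45%, within a range from 15% to 75%. This estimate means a step of a number 34 percentage points higher from compound 2 to compound 4 (beyond the scatter) is expected.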

Compound 4, a percentage reported as inhibition, at one concentration (the size of the read-out at that concentration, not a potency): 40%
Compound 4: the middle estimate sits 5 percentage points above what was measured; measured number inside the range.
By their numbers in this assay, from the lowest: compound 2; then compound 4; then compound 3.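

With a third aryl group on this carbonyl carbon, the effect in this assay no longer rests on a single contrast: the change to 3-(dimethylamino)phenyl gives a number 29 percentage points higher from compound 2 to compound 4 (beyond the scatter), and it also gives a number 33 percentage points lower from compound 3 to compound 4 (beyond the scatter). Losing the 2-carbamoylphenyl group therefore does not by itself carry the number to the level of compound 3, and the group that enters matters as well. The 2-carbamoylphenyl and 3-(dimethylamino)phenyl groups match in heavy-atom count and in hydrogen-bond acceptor count, differing in that the first carries a hydrogen-bond donor and a double bond outside the ring, but nothing in the data shown accounts for the difference in effect.

From the compounds shown here alone, it remains open whether the gap between compound 3 and compound 4 follows the nature of the group or its place on the phenyl ring, as 4-(trifluoromethoxy)phenyl and 3-(dimethylamino)phenyl differ in both at once. A 4-(dimethylamino)phenyl or a 3-(trifluoromethoxy)phenyl group on the same carbonyl carbon would separate these two changes, and how a phenyl bearing a carboxylic acid would read in this assay is likewise unknown.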